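A Sulfonyl Ester Follows Two Carbonyl Esters Into Cytotoxicity Testing

The compounds below may be only part of what the source reports. "The series", "measured", "known", "first", "only" and "open" are said of these compounds alone.

Compound 1 `COc1ccc(/C=C/C(=O)c2ccc(OC)c3c2OC(C)(C)C=C3)cc1OC(=O)C(C)C` and compound 2 `C=CC(=O)Oc1cc(/C=C/C(=O)c2ccc(OC)c3c2OC(C)(C)C=C3)ccc1OC` share one core and differ only at a single ester group. In an ADME assay on L02 cells (Homo sapiens) for cytotoxicity, read by MTT assay (a lower number here means a stronger inhibitor, a higher number a weaker inhibitor), compound 1 gives > 10000 nM, which is a limit of the assay rather than a number. In this assay compound 2 likewise gives > 10000 nM, again a limit. The step that the two limits leave unreadable from compound 1 to compound 2 cannot be read, since both values sit at the limit of > 10000 nM in this assay, at which 2 of the 2 values shown sit. Compound 3 `COc1ccc(/C=C/C(=O)c2ccc(OC)c3c2OC(C)(C)C=C3)cc1OS(=O)(=O)c1ccc(C)cc1` is not yet measured; it differs from compound 2 in that ((4-methylphenyl)sulfonyl in place of vinylcarbonyl on an oxygen on an aromatic ring). Going by the values given here, no measured step bears directly on this change: the only measured step concerns a different group, and its size is not readable. Compound 2 stands at the limit, so the numbers give no direction for the change. Given that both values shown sit at the limit of > 10000 nM in this assay, at which 2 of the 2 values shown sit, compound 3 is expected to remain near that limit as well. The step that the limit leaves unreadable from compound 2 to compound 3 is estimated to be small. For compound 3 the expected value in this assay is 20000 nM, with a range from 8000 nM to 80000 nM.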

Compound 3, half-maximal inhibitory concentration: > 10000 nM
Compound 3 was reported as a limit; the forecaster's own chance of this, stated with the estimate: 75%; the middle value is on the limit's open side.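

In this assay compound 3 gives > 10000 nM, which is a limit of the assay and not a number. The steps to compound 3 from compound 1 and from compound 2 therefore cannot be read: the limit of > 10000 nM in this assay, at which 3 of the 3 values shown sit. The compounds shown leave open how the (4-methylphenyl)sulfonyl, vinylcarbonyl and isopropylcarbonyl groups compare in this assay.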